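Swapping ethyl for fluoro in compound 3

The compounds below may be only part of what the source reports. "The series", "measured", "known", "first", "only" and "open" are said of these compounds alone.

Compound 1 `CC(C)CN(c1ccc(C#N)cc1)S(=O)(=O)c1ccc2c(c1)C(=O)CC(C1CCOCC1)O2`: 3.16
Compound 2 `CC(C)CN(c1ccc(F)cc1F)S(=O)(=O)c1ccc2c(c1)C(=O)CC(C1CCOCC1)O2`: 3.62
Compound 3 `CCc1ccc(N(CC(C)C)S(=O)(=O)c2ccc3c(c2)C(=O)CC(C2CCOCC2)O3)cc1`: 4.21

Of these three compounds, measured in a physicochemical assay for lipophilicity, at pH 7.4 (on this read-out higher numbers stand for higher lipophilicity and lower numbers for lower lipophilicity), compound 3 stands highest at 4.21. Compound 4 `CC(C)CN(c1ccc(F)cc1)S(=O)(=O)c1ccc2c(c1)C(=O)CC(C1CCOCC1)O2` has not yet been measured. It differs from compound 3 in one place: fluoro in place of ethyl on an aromatic carbon. This puts fluoro in place of ethyl on an aromatic carbon, para to a large group.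

Within the data shown here, no measured compound carries 4-fluorophenyl itself, but two steps offer guidance. The closest is a number 0.59 log units higher from compound 2 to compound 3 (beyond the scatter), which is modest and exchanges 2,4-difluorophenyl for 4-ethylphenyl. The other is a number 1.05 log units higher from compound 1 to compound 3 (beyond the scatter), which is large and shows that replacing the group at this same place can move the number considerably. Read in reverse, the closer step suggests a modest fall in this assay, beyond the scatter. The expected step is a number 0.66 log units lower from compound 3 to compound 4 (beyond the scatter). For compound 4 the estimated value is 3.55, with an expected range from 3.25 to 3.85.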

Compound 4, distribution coefficient: 3.48
The estimate for compound 4 lay 0.07 log units above the measured number; the measured number falls inside the stated range.
By their numbers in this assay, from the lowest: compound 1; then compounds 4 and 2 (each within the scatter of the next); then compound 3.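

In this assay, among these compounds, the single fluoro on the ring at the sulfonamide nitrogen gives a cleaner reading of this place than the earlier compounds could. Fluoro in place of ethyl gives a number 0.73 log units lower from compound 3 to compound 4 (beyond the scatter), while fluoro in place of cyano gives a number 0.32 log units higher from compound 1 to compound 4 (beyond the scatter), so among these three compounds the groups at this carbon, para to a large group, rank cyano, then fluoro, then ethyl. Hydrogen in place of the second fluoro of compound 2 gives a number 0.14 log units lower from compound 2 to compound 4 (within the scatter), so much of the earlier step from compound 2 to compound 3 can be read as the change from fluoro to ethyl, not as an effect of that second fluoro.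

On these data alone, whether an amine, a carboxylic acid or a chain longer than ethyl at this carbon would fall outside this span remains open. Nothing available gives a cause for these differences.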